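The source may report more compounds than this note shows. Statements on the series, on what has been measured and on what is new or still open speak of the compounds shown alone.

Compound 1 `CCCCCCCCCCc1cc2cn([C@H]3C[C@H](O)[C@@H](CO)O3)c(=O)nc2o1` carries a decyl chain on the shared core. In a functional assay on HEL cells (Homo sapiens) for cytotoxicity (on this read-out lower numbers stand for higher toxicity in this test and higher numbers for lower toxicity in this test), compound 1 gives only a limit, > 50000 nM, and no number. For the measured compounds named here, compound 2 `O=c1nc2oc(CCCCCCCCCF)cc2cn1[C@H]1C[C@H](O)[C@@H](CO)O1` is the only compound of the pair with a number: in this assay compound 2 gives 200000 nM. Going by the values given here, the single measured step, a step that the limit leaves unreadable from compound 1 to compound 2, cannot be sized because the limit of > 50000 nM in this assay, at which 1 of the 2 values shown sits, hides its start. Compound 3 `O=c1nc2oc(CCCCCCCCCCl)cc2cn1[C@H]1C[C@H](O)[C@@H](CO)O1` differs from compound 2 by chloro in place of fluoro on a saturated chain carbon, nine bonds along the chain from an aromatic carbon. Among the compounds with values here, no measured step bears on that exchange, so for compound 3 a step of a 1.3-fold lower number from compound 2 to compound 3 (0.12 log units; within the scatter) within the scatter is expected. Compound 3 is estimated at 150000 nM, between 50000 nM and 400000 nM.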

Compound 3, half-maximal cytotoxic concentration: 200000 nM
Compound 3: the middle estimate sits 1.3-fold (0.12 log units) below what was measured; the range from low to high includes it.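

In this assay chloro in place of fluoro on a saturated chain carbon, nine bonds along the chain from an aromatic carbon, shows no change at the digits printed from compound 2 to compound 3 (within the scatter) and so leaves the read-out unmoved at this position, which compound 2 alone could not show. Compound 1 holds only a limit, and its step to compound 3 cannot be read: the limit of > 50000 nM in this assay, at which 1 of the 3 values shown sits.

As far as these compounds go, whether a hydroxyl, an amine or a carboxylic acid at this position would read differently stays open. So does the reading for a longer chain carrying chloro.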